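This account rests on a few compounds, and the source may have more. Where it says the series, first, only, none or still open, it means among the compounds named here.

Measured compounds:
compound 1, `CC(C(=O)NCc1ccc(C(C)(C)C)nc1N1CCCC1)c1ccc(NS(C)(=O)=O)c(F)c1`: 1.2 nM in an assay on cells for antagonist activity at transient receptor potential cation channel subfamily V member 1 (Homo sapiens), read by FLIPR and calcium flux, with a stated time of 6 min; a higher number here means a weaker inhibitor, a lower number a stronger inhibitor
compound 2, `CCCCOc1cc(C(C)(C)C)ccc1CNC(=O)C(C)c1ccc(NS(C)(=O)=O)c(F)c1`: 1.4 nM

In this assay compound 1 gives 1.2 nM and compound 2 gives 1.4 nM; the two numbers lie within the usual scatter of each other, so compound 2 stands level with compound 1. Compound 3, `CCCCSc1cc(C(C)(C)C)ccc1CNC(=O)C(C)c1ccc(NS(C)(=O)=O)c(F)c1`, differs from compound 2 in one place: butylsulfanyl in place of butoxy on an aromatic carbon. Among the measured compounds shown here, no measured pair with this kind of change exists here, so the change is expected to shift the number little, if at all, beyond the scatter. The step of a 1.1-fold higher number from compound 2 to compound 3 (0.06 log units; within the scatter) is therefore estimated to be small. Compound 3 is expected to give 1.6 nM, with a likely range from 0.6 nM to 4.5 nM.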

Compound 3, inhibition constant: 6.7 nM
For compound 3 the middle estimate is 4.2-fold (0.62 log units) below the measured one, outside the stated range (above it).
By their numbers in this assay, from the lowest: compounds 1 and 2 (each within the scatter of the next); then compound 3.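

In this assay, butylsulfanyl in place of butoxy gives a 4.8-fold higher number from compound 2 to compound 3 (0.68 log units; beyond the scatter) and so this position, ortho to a large group, responds to an exchange of oxygen for sulfur. The two groups match in heavy-atom count and in hydrogen-bond donors and acceptors, so those counts alone do not settle the number here. No measurement given here accounts for the step. Still open, going by these compounds, is whether butylamino, with nitrogen as the linking atom, or the shorter propoxy would stay level with compound 2 or move towards compound 3.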